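This account rests on a few compounds, and the source may have more. Where it says the series, first, only, none or still open, it means among the compounds named here.

In a functional assay on A549 cells (Homo sapiens) for cytotoxicity, read by MTT assay, with a stated time of 4 days (on this read-out lower numbers stand for stronger inhibition and higher numbers for weaker inhibition), three compounds have been measured so far:

Compound 1 `C=C1C(=O)[C@]23C[C@@]1(O)CC[C@H]2c1ccc(OS(=O)(=O)c2ccc(C)cc2)c(C)c1[C@@H]3Cn1cc(-c2ccc(Br)cc2)nn1` gives 1630 nM
Compound 2 `C=C1C(=O)[C@]23C[C@@]1(O)CC[C@H]2c1ccc(O)c(C)c1[C@@H]3Cn1cc(-c2ccc(C(F)(F)F)cc2)nn1` gives 1110 nM
Compound 3 `C=C1C(=O)[C@]23C[C@@]1(O)CC[C@H]2c1ccc(O)c(C)c1[C@@H]3Cn1cc(-c2ccc(Cl)cc2)nn1` gives 640 nM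

Compound 3 has the lowest of these three numbers. Its number and that of compound 2 lie within the scatter of each other, so no order between them can be claimed; only the gap to compound 1 lies beyond it. Among the measured compounds shown here, the single one-place step among the measured compounds is a 1.7-fold lower number from compound 2 to compound 3 (0.24 log units; within the scatter), a swap of one group at the same position of the phenyl ring attached to the triazole, and it did not move the number beyond the scatter.

Compound 4 `C=C1C(=O)[C@]23C[C@@]1(O)CC[C@H]2c1ccc(O)c(C)c1[C@@H]3Cn1cc(-c2ccc(Br)cc2)nn1` differs from compound 3 in just that position: bromo in place of chloro on an aromatic carbon. For the measured compounds named here, the one step that bears on it, from compound 2 to compound 3, exchanged groups at this very carbon and stayed within the scatter. Exchanging one halogen for a neighbouring halogen is therefore expected to move the number little, if at all. For compound 4 in this assay the expected step of a 1.1-fold higher number from compound 3 to compound 4 (0.04 log units; within the scatter) lies within the scatter. Compound 4 is estimated at 700 nM, with a likely range from 350 nM to 1400 nM.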

Compound 4, half-maximal inhibitory concentration: 1140 nM
Beside the measured number, compound 4's estimate is 1.6-fold (0.21 log units) below it; measured number inside the range.
By their numbers in this assay, from the lowest: compounds 3, 2, 4 and 1 (each within the scatter of the next, the first and the last beyond it).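

In this assay, the exchange of chloro for bromo on the phenyl ring is a 1.8-fold higher number from compound 3 to compound 4 (0.25 log units; within the scatter), and the exchange of trifluoromethyl for bromo at that same carbon is a 1.0-fold higher number from compound 2 to compound 4 (0.01 log units; within the scatter), so all three groups tried at this carbon now lie within the scatter of one another, and no order among them can be claimed. Compound 4 also gives the first one-place view of the oxygen on the aromatic ring of the core: replacing (4-methylphenyl)sulfonyl with hydrogen there is a 1.4-fold lower number from compound 1 to compound 4 (0.16 log units; within the scatter), so this large change does not move the number beyond the scatter either. No measurement is available that could explain why these numbers stay so close together.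

The compounds shown leave open whether a group of another kind on that phenyl carbon, such as an amine or a carboxylic acid, would shift the number beyond the scatter. They also leave open whether a small group on the oxygen, such as methyl, would do so, and whether any single change at either place can separate these compounds clearly in this cell assay.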